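Trifluoromethylphenyl amide in a cyclopropane-linked series

The source may hold more compounds than are shown below. What is called first, only, known or untested is meant among the compounds shown, and "the series" means these compounds.

Compound 3 `COC(=O)c1cccc(NC(=O)C2(C(=O)Nc3ccc(Nc4ncc5cc(C(=O)N(C)C)n(C6CCCC6)c5n4)cc3)CC2)c1` stands second highest of three numbers in a functional assay on A549 cells (Homo sapiens) for inhibition, read by CCK-8 assay, with a stated time of 72 h, tested at 10 uM (a lower number here means less inhibition of growth, a higher number more inhibition of growth at the concentration tested), where compound 3 gives 91%. Its neighbours are compound 1 `CN(C)C(=O)c1cc2cnc(Nc3ccc(NC(=O)C4(C(=O)Nc5cccc(Cl)c5)CC4)cc3)nc2n1C1CCCC1` with 90.7% and compound 2 `COC(=O)c1ccc(NC(=O)C2(C(=O)Nc3ccc(Nc4ncc5cc(C(=O)N(C)C)n(C6CCCC6)c5n4)cc3)CC2)cc1` with 92%, and all three lie within the scatter of one another: a number 0.3 percentage points higher from compound 1 to compound 3 (within the scatter), a number 1 percentage points lower from compound 2 to compound 3 (within the scatter) and a number 1.3 percentage points higher from compound 1 to compound 2 (within the scatter). Compound 4 `CN(C)C(=O)c1cc2cnc(Nc3ccc(NC(=O)C4(C(=O)Nc5ccc(C(F)(F)F)cc5)CC4)cc3)nc2n1C1CCCC1` differs from compound 3 by 4-(trifluoromethyl)phenyl in place of 3-(methoxycarbonyl)phenyl on an amide-type nitrogen. Each measured step already exchanges the aryl group on that amide-type nitrogen, and none moved beyond the scatter, so no step beyond the scatter is expected in this assay: a number 1 percentage points lower from compound 3 to compound 4 (within the scatter). Compound 4 is therefore estimated at 90%, in a range from 82% to 96%.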

Compound 4, percent growth inhibition at one concentration: 87.9%
Compound 4: middle estimate off by 2.1 percentage points, on the high side, and the stated range covers the measured number.
By their numbers in this assay, from the lowest: compounds 4, 1, 3 and 2 (each within the scatter of the next).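

With 4-(trifluoromethyl)phenyl on the amide-type nitrogen, the reading in this assay stays within the scatter of all three earlier compounds (a number 3.1 percentage points lower from compound 3 to compound 4 (within the scatter); a number 2.8 percentage points lower from compound 1 to compound 4 (within the scatter)). Trifluoromethyl in place of methoxycarbonyl on the same aromatic carbon also leaves it there (a number 4.1 percentage points lower from compound 2 to compound 4 (within the scatter)), so this 4-substituted ring no longer depends on methoxycarbonyl, with its two hydrogen-bond acceptors, among these compounds. Nothing available explains these readings. The compounds shown leave open whether an amine or a carboxylic acid in place of trifluoromethyl would keep the reading within the scatter. They also cannot rank these four groups at this single concentration.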